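Inverting the stereocentre of compound 2

A few compounds are considered here, and "the series" means these few. Any claim that something is new, unique, unknown or untested is made for them only; others in the source may bear on it.

Values in a functional assay on CWR22R cells (Homo sapiens) for antiproliferative activity, read by CCK-8 assay, with a stated time of 6 days (a lower number here means a stronger inhibitor, a higher number a weaker inhibitor), are as follows:
- compound 1 `C[C@@H](Cn1ccc(-c2ccc(C#N)c(Cl)c2)n1)Nc1ccc2ccccc2n1` gives 7950 nM
- compound 2 `C[C@@H](Cn1ccc(-c2ccc(C#N)c(Cl)c2)n1)Nc1ncnc2ccccc12` gives 4360 nM

Compound 2 stands within the scatter of compound 1, so these two values set no order between them. Neither compound is marked out as the better one, and a pair this small shows no trend.

The compound still to be measured is compound 3 `C[C@H](Cn1ccc(-c2ccc(C#N)c(Cl)c2)n1)Nc1ncnc2ccccc12`, and the step from compound 2 is purely one of configuration: the two compounds have the same atoms and bonds and differ only in configuration as drawn: 1 of 1 stereo elements differ; a stereocentre at a saturated chain carbon is drawn S in compound 2 and R in compound 3. A stereocentre at a saturated chain carbon is drawn S in compound 2 and R in compound 3.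

Within the data shown here, no measured pair shows what such an inversion does, so the data give no direct size for this step. In this assay no change beyond the scatter is expected, with only a slight lean towards a higher number. The estimated 1.3-fold higher number from compound 2 to compound 3 (0.10 log units; within the scatter) is therefore small. The uncertainty stays wide, since an inversion could still matter more than expected.

For compound 3 the expected value is 5500 nM, with an estimated range from 2200 nM to 14000 nM.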

Compound 3, half-maximal inhibitory concentration: 9710 nM
The estimate for compound 3 lay 1.8-fold (0.25 log units) below the measured number; measured number inside the range.
By their numbers in this assay, from the lowest: compounds 2, 1 and 3 (each within the scatter of the next, the first and the last beyond it).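

In this assay, among these compounds, a 2.2-fold higher number from compound 2 to compound 3 (0.35 log units; beyond the scatter), the first step that reads on this stereocentre at a saturated chain carbon, and the S form as drawn holds the lower number. With atoms and bonds unchanged, the step can be assigned to the configuration alone, because nothing else separates the pair: the fact that compounds 2 and 3 differ only in the configuration as drawn

The earlier values could not show that this position responds to inversion at all; the step is modest, but it lies beyond the scatter, so configuration here has to be tracked as a variable in this series.

From the compounds shown here alone, whether the same preference for the S form holds on the core of compound 1 remains open, since a single pair on one core fixes neither its generality nor its size elsewhere. Also open, going by these compounds, is whether a longer chain in place of the methyl at this stereocentre, or an amine carried on that chain, would widen or close the gap between the two configurations.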